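Aryl change on the amide nitrogen: compound 1 to compound 4

The source may hold more compounds than are shown below. What is called first, only, known or untested is meant among the compounds shown, and "the series" means these compounds.

Measured in an assay on isolated protein for inhibition of glutathione S-transferase Mu 2 (Homo sapiens), with a stated time of 10 min; a lower number here means a stronger inhibitor, a higher number a weaker inhibitor:
compound 1 `O=C(CCC(=O)OCCCCCCSc1ccc([N+](=O)[O-])c2nonc12)Nc1ccccc1Cl`: 330 nM
compound 2 `COc1ccccc1NC(=O)CCC(=O)OCCCCCCSc1ccc([N+](=O)[O-])c2nonc12`: 280 nM
compound 3 `O=C(CCC(=O)OCCCCCCSc1ccc([N+](=O)[O-])c2nonc12)Nc1ccc(F)cc1`: 320 nM

Compound 1 gives the highest of the three numbers, yet the steps of a 1.2-fold lower number from compound 1 to compound 2 (0.07 log units; within the scatter) and a 1.0-fold lower number from compound 1 to compound 3 (0.01 log units; within the scatter) both lie within the scatter, as does a 1.1-fold higher number from compound 2 to compound 3 (0.06 log units; within the scatter); the three compounds are not separated in this assay. Compound 4 `O=C(CCC(=O)OCCCCCCSc1ccc([N+](=O)[O-])c2nonc12)Nc1ccc(Br)cc1` differs from compound 1 by 4-bromophenyl in place of 2-chlorophenyl on an amide-type nitrogen. The step that bears on it most directly is a 1.0-fold lower number from compound 1 to compound 3 (0.01 log units; within the scatter), where one halogen on the aryl group gave way to another without effect beyond the scatter. No step beyond the scatter is therefore expected; the estimated step is a 1.0-fold lower number from compound 1 to compound 4 (0.01 log units; within the scatter). Compound 4 is expected to give 320 nM in this assay, with a range from 150 nM to 700 nM.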

Compound 4, half-maximal inhibitory concentration: 32000 nM
Compound 4: middle estimate off by 100-fold (2.00 log units), on the low side, outside the stated range (above it).
By their numbers in this assay, from the lowest: compounds 2, 3 and 1 (each within the scatter of the next); then compound 4.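

In this assay, within the data shown here, the aryl group on the amide-type nitrogen does matter: a 97-fold higher number from compound 1 to compound 4 (1.99 log units; beyond the scatter) and a 110-fold higher number from compound 2 to compound 4 (2.06 log units; beyond the scatter) show that the flat picture from the earlier compounds does not hold for 4-bromophenyl. Among these compounds, with a 100-fold higher number from compound 3 to compound 4 (2.00 log units; beyond the scatter) as the reading, bromo in place of fluoro is the only change, so 4-fluorophenyl and 4-bromophenyl are not interchangeable at this position.

Nothing available bears on the cause of this drop. Going by these compounds, whether chloro, iodo or methyl in place of bromo in 4-bromophenyl also gives a weak inhibitor remains open.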